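Vinyl for Fluoro: What to Expect at the Receptor

A few compounds are considered here, and "the series" means these few. Any claim that something is new, unique, unknown or untested is made for them only; others in the source may bear on it.

Compound 1 `Brc1ccc2ccn(CCN3CCCN4CCCCC4C3)c2c1`: 99%
Compound 2 `CN1CCCN(CCn2ccc3cccc(Br)c32)CC1`: 18%
Compound 3 `CN1CCCN(CCn2ccc3ccc(F)cc32)CC1`: 60%

In an assay on HEK293 cells for binding affinity to 5-hydroxytryptamine receptor 7 (Homo sapiens), read by radioligand binding, tested at 1 uM (a higher number here means more inhibition at the concentration tested (going by the name of the read-out), a lower number less inhibition), compound 3 stands second of the three measured compounds: compound 1 lies higher and compound 2 lies lower, both by more than the usual scatter. Compound 4 `C=Cc1ccc2ccn(CCN3CCCN(C)CC3)c2c1` has not yet been measured. It differs from compound 3 in a single place: vinyl in place of fluoro on an aromatic carbon. For the measured compounds named here, no measured pair in this set shows a change of this kind, so nothing here tells how large such a step is. A modest rise in this assay is expected, near the edge of the scatter; the expected step is a number 15 percentage points higher from compound 3 to compound 4 (beyond the scatter). Compound 4 is therefore estimated at 75%, within a range from 50% to 95%.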

Compound 4, a percentage reported as inhibition, at one concentration (the size of the read-out at that concentration, not a potency): 79%
Compound 4: the middle estimate sits 4 percentage points below what was measured; the measured number falls inside the stated range.
By their numbers in this assay, from the lowest: compound 2; then compound 3; then compound 4; then compound 1.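

In this assay, for the compounds shown here, this is the first comparison in the set where only one group changes, and the step is a number 19 percentage points higher from compound 3 to compound 4 (beyond the scatter). At this aromatic carbon, then, replacing fluoro with vinyl, which has one more heavy atom and a double bond outside the aromatic rings, goes with more inhibition rather than less. Nothing available explains why the number rises.

On these data alone, it remains open whether an ethyl group, a saturated counterpart of vinyl, would give a similar number at this carbon, and how an amine or a carboxylic acid would fare there. Also open, as far as these compounds go, is whether the same swap would give a similar step on the core of compound 1.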